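The compounds below may be only part of what the source reports. "The series", "measured", "known", "first", "only" and "open" are said of these compounds alone.

Values measured in a functional assay on HCT-116 cells (Homo sapiens) for antiproliferative activity, read by MTT assay, with a stated time of 72 h; a higher number here means a weaker inhibitor, a lower number a stronger inhibitor:
- compound 1 `O=C(CCc1cccc2c1B(O)OC2)Nc1ccccc1`: 350 nM
- compound 2 `O=C(CCc1cccc2c1B(O)OC2)Nc1cccc(-c2ccc(F)cc2)c1`: 550 nM

Among the compounds with values here, compound 2, at 550 nM, lies within the usual scatter of compound 1, the only other compound measured so far. The next compound, compound 3 `O=C(CCc1cccc2c1B(O)OC2)Nc1cccc(-c2ccc(Cl)cc2)c1`, has chloro in place of fluoro on an aromatic carbon, para to a large group: chloro in place of fluoro on an aromatic carbon. In other words, 4-chlorophenyl replaces 4-fluorophenyl. Within the data shown here, no measured pair makes this exact exchange. The nearest evidence is a 1.6-fold higher number from compound 1 to compound 2 (0.20 log units; within the scatter), which came from adding the whole 4-fluorophenyl group in place of hydrogen. Since even that larger change stayed within the scatter, this single-atom exchange is expected to produce no shift beyond the scatter in this assay, and no direction is favoured. The expected size is a 1.1-fold lower number from compound 2 to compound 3 (0.04 log units; within the scatter). For compound 3 the estimated value is 500 nM, with an expected range of 220 nM to 1200 nM.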

Compound 3, half-maximal inhibitory concentration: 380 nM
Beside the measured number, compound 3's estimate is 1.3-fold (0.12 log units) above it; the measured number falls inside the stated range.
By their numbers in this assay, from the lowest: compounds 1, 3 and 2 (each within the scatter of the next).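

In this assay the exchange of 4-fluorophenyl for 4-chlorophenyl now has a direct reading (a 1.4-fold lower number from compound 2 to compound 3 (0.16 log units; within the scatter)), so this single-atom exchange on an aromatic carbon, para to a large group, does not separate the two compounds. Placing 4-chlorophenyl on the ring in place of hydrogen gives a similar reading (a 1.1-fold higher number from compound 1 to compound 3 (0.04 log units; within the scatter)), so neither of the two halogen-bearing phenyl groups shown can be told apart from hydrogen at this place. Nothing available explains why these values stay so close.

The compounds shown leave open whether a different kind of group at this place, such as an amine, a carboxylic acid or a longer chain, would move the number beyond the scatter. From the compounds shown here alone, all three share the core of compound 1, so the effect of changes to that core also remains unknown.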